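The source may report more compounds than this note shows. Statements on the series, on what has been measured and on what is new or still open speak of the compounds shown alone.

Of the compounds shown here, three with a shared core have been measured in a physicochemical assay for solubility, in phosphate buffer, with a stated time of 18 h, at pH 7 (on this read-out higher numbers stand for higher solubility and lower numbers for lower solubility), and they differ only in the group on a saturated ring carbon. There compound 1 `CC(=O)N1CCCC([C@@H]2[C@@H](C(=O)Nc3ccc(F)c(C#N)c3)c3ccccc3C(=O)N2CC(C)C)C1` gives 69000 nM, compound 2 `CC(C)CN1C(=O)c2ccccc2[C@H](C(=O)Nc2ccc(F)c(C#N)c2)[C@H]1c1ccc(C(N)=O)s1` gives 19000 nM and compound 3 `CC(C)CN1C(=O)c2ccccc2[C@H](C(=O)Nc2ccc(F)c(C#N)c2)[C@H]1c1cnn(C)c1` gives 36000 nM. The value of compound 3 lies within the usual scatter of both others, so it cannot be ranked against either. The two steps that show this are a 1.9-fold lower number from compound 1 to compound 3 (0.28 log units; within the scatter) and a 1.9-fold higher number from compound 2 to compound 3 (0.28 log units; within the scatter). Only a 3.6-fold lower number from compound 1 to compound 2 (0.56 log units; beyond the scatter) goes beyond the scatter, and it is modest.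

Compound 4 `CC(C)CN1C(=O)c2ccccc2[C@H](C(=O)Nc2ccc(F)c(C#N)c2)[C@H]1c1ccno1` carries 1,2-oxazol-5-yl in place of 1-methyl-1H-pyrazol-4-yl on a saturated ring carbon, and the counted difference is 1,2-oxazol-5-yl in place of 1-methyl-1H-pyrazol-4-yl on a saturated ring carbon. One five-membered aromatic ring with 2 hetero atoms replaces another, at the same carbon as in all three measured steps. Within the data shown here, the closest precedent, an exchange of one aromatic group for another, is a 1.9-fold higher number from compound 2 to compound 3 (0.28 log units; within the scatter), which stayed within the scatter. Among the measured compounds shown here, with only three compounds to go on, no change beyond the scatter is expected, and the estimated step is a 1.1-fold lower number from compound 3 to compound 4 (0.05 log units; within the scatter) in this assay. The estimate for compound 4 is 32000 nM, with an expected range from 13000 nM to 75000 nM.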

Compound 4, solubility: 53000 nM
Estimate against measurement, compound 4: 1.7-fold (0.22 log units) below, and the stated range covers the measured number.
By their numbers in this assay, from the lowest: compounds 2, 3, 4 and 1 (each within the scatter of the next, the first and the last beyond it).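

In this assay, exchanging one five-membered aromatic ring for another on this saturated ring carbon gives a 1.5-fold higher number from compound 3 to compound 4 (0.17 log units; within the scatter) and so does not separate 1,2-oxazol-5-yl from 1-methyl-1H-pyrazol-4-yl, even though the entering group has fewer heavy atoms and carries an oxygen. The comparison with the other two groups is mixed: there is a 2.8-fold higher number from compound 2 to compound 4 (0.45 log units; beyond the scatter) as a second modest step beyond the scatter, yet compound 2 remains within the scatter of compound 3, so 5-carbamoylthiophen-2-yl does not stand apart from both five-membered rings with 2 hetero atoms. There is also a 1.3-fold lower number from compound 1 to compound 4 (0.11 log units; within the scatter) and this stays within the scatter, which means that a non-aromatic group and an aromatic ring at this carbon can give numbers that cannot be told apart, and no measurement at hand explains any of these numbers.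

As far as these compounds go, how an amine or a carboxylic acid on this carbon would read out in this assay stays open. Also open, from the compounds shown here alone, is whether a longer chain in place of the isobutyl group would leave these small differences between the rings unchanged.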